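Compound 4: a new chain on the shared core

The source may hold more compounds than are shown below. What is called first, only, known or untested is meant among the compounds shown, and "the series" means these compounds.

Measured so far in a physicochemical assay for solubility, read by HPLC; on this read-out higher numbers stand for higher solubility and lower numbers for lower solubility
compound 1 (`Cc1cc2c(c(N)nn2C)c(=O)[nH]1`) gives 1220 ug/mL
compound 2 (`Cn1nc(N)c2c(=O)[nH]c(-c3ccccc3)cc21`) gives 76 ug/mL
compound 3 (`Cn1nc(N)c2c(=O)[nH]c(C3CCNCC3)cc21`) gives a limit, > 15000 ug/mL

Going by the values given here, compound 1 holds the higher of the two numbers, and the gap to the only other number is large (a 16-fold lower number from compound 1 to compound 2 (1.21 log units; beyond the scatter)). The third value, from compound 3, is a limit and gives no rank.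

Compound 4 (`COC(=O)CCc1c(C)[nH]c(=O)c2c(N)nn(C)c12`) keeps the core of compound 1 and its methyl group, and gains a chain (2-(methoxycarbonyl)ethyl in place of hydrogen on an aromatic carbon). This is 2-(methoxycarbonyl)ethyl in place of hydrogen on an aromatic carbon, ortho to that methyl group.

Among the compounds with values here, no measured step replaces this hydrogen. All three exchange the group at the methyl place, so they bear on the change only loosely. They are large and point in opposite directions (a 16-fold lower number from compound 1 to compound 2 (1.21 log units; beyond the scatter); an at least 12-fold higher number from compound 1 to compound 3 (1.08 log units; beyond the scatter)), and the gap between the two substituents is wider still (an at least 190-fold higher number from compound 2 to compound 3 (2.29 log units; beyond the scatter)). With an added group that has no ring and no net charge, a lower number is expected, though well short of the drop seen with phenyl (a 16-fold lower number from compound 1 to compound 2 (1.21 log units; beyond the scatter)).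

The expected step in this assay is therefore modest and downward (a 2.4-fold lower number from compound 1 to compound 4 (0.39 log units; beyond the scatter)). For compound 4 the estimated value is 500 ug/mL (expected range 120 ug/mL to 1800 ug/mL).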

Compound 4, solubility: 469 ug/mL
The estimate for compound 4 lay 1.1-fold (0.03 log units) above the measured number, within the range that was stated.
By their numbers in this assay, from the lowest: compound 2; then compound 4; then compound 1. At a limit, above all of these: compound 3.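

Working notes on the position. In this assay, the aromatic carbon ortho to a methyl group now has a direct reading: 2-(methoxycarbonyl)ethyl in place of hydrogen gives a 2.6-fold lower number from compound 1 to compound 4 (0.42 log units; beyond the scatter) with the methyl group kept. Going by these compounds alone, the earlier steps all exchanged the group at the methyl place, so this is the first sign that the number also moves at a second place on the shared core, and with a chain that has no ring and no net charge the step is modest, set against the large 16-fold lower number from compound 1 to compound 2 (1.21 log units; beyond the scatter) at the methyl place. Nothing in the data shown accounts for the size or direction of this step.

Going by these compounds, it remains open whether the step belongs to the methoxycarbonyl end or to the added chain as such, and a carboxylic acid, an amine or a longer chain on this carbon would separate the two. On these data alone, compound 3 gives only a limit, > 15000 ug/mL, and the effect of this chain alongside a piperidin-4-yl group also stays open.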